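Cyclohexyl in place of 4-chlorophenyl on an aromatic nitrogen

A few compounds are considered here, and "the series" means these few. Any claim that something is new, unique, unknown or untested is made for them only; others in the source may bear on it.

The series is read in a functional assay on HT-29 cells (Homo sapiens) for cytotoxicity, read by MTT assay, with a stated time of 48 h; a higher number here means a weaker inhibitor, a lower number a stronger inhibitor. Compound 1 `O=C1C[C@H](OCc2cn(-c3ccc(Cl)cc3)nn2)[C@H]2CO[C@@H]1O2` gives 14700 nM. Compound 2 `O=C1C[C@H](OCc2cn(-c3ccccc3)nn2)[C@H]2CO[C@@H]1O2` gives 13400 nM, and compound 3 `C=C(C)Cn1cc(CO[C@H]2CC(=O)[C@@H]3OC[C@H]2O3)nn1` gives 17200 nM. Among the three numbers compound 1 stands second highest; the nearest number is a 1.1-fold lower number from compound 1 to compound 2 (0.04 log units; within the scatter) and the furthest is a 1.2-fold higher number from compound 1 to compound 3 (0.07 log units; within the scatter). Between the other two there is a 1.3-fold higher number from compound 2 to compound 3 (0.11 log units; within the scatter). None of these steps goes beyond the scatter, so the three compounds cannot be placed in order.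

Compound 4 `O=C1C[C@H](OCc2cn(C3CCCCC3)nn2)[C@H]2CO[C@@H]1O2` has not yet been measured. Relative to compound 1 the change is cyclohexyl in place of 4-chlorophenyl on an aromatic nitrogen. Among the measured compounds shown here, two measured steps bear on this position: the step from compound 1 to compound 2, which takes the chloro off the aromatic carbon, and the step from compound 1 to compound 3, which puts a 2-methylprop-2-en-1-yl chain on the aromatic nitrogen in place of the aryl group. Both stay within the scatter, as does the step between compound 2 and compound 3. Nothing here shows that the group on this aromatic nitrogen moves the number in this assay. For compound 4 the expected step is therefore a 1.0-fold higher number from compound 1 to compound 4 (0.01 log units; within the scatter), that is, none beyond the scatter. Compound 4 is estimated at 15000 nM, with a range from 7000 nM to 32000 nM.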

Compound 4, half-maximal inhibitory concentration: 11900 nM
Beside the measured number, compound 4's estimate is 1.3-fold (0.10 log units) above it; the range from low to high includes it.
By their numbers in this assay, from the lowest: compounds 4, 2, 1 and 3 (each within the scatter of the next).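

In this assay, replacing the aromatic 4-chlorophenyl with the non-aromatic cyclohexyl gives a 1.2-fold lower number from compound 1 to compound 4 (0.09 log units; within the scatter), so the set now includes a non-aromatic carbon ring on this aromatic nitrogen and the step stays within the scatter. The comparisons with the open chain and the unsubstituted aryl group read the same way, with a 1.4-fold lower number from compound 3 to compound 4 (0.16 log units; within the scatter) and a 1.1-fold lower number from compound 2 to compound 4 (0.05 log units; within the scatter), so the four groups on this nitrogen (4-chlorophenyl, phenyl, 2-methylprop-2-en-1-yl and cyclohexyl) cannot be separated in this assay. No measurement at hand offers a reason for this flat reading.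

Open, going by these compounds, is whether a group of another kind on this aromatic nitrogen, such as an amine, a carboxylic acid or a longer alkyl chain, would give a step beyond the scatter. Also open, on these data alone, is whether a hydroxyl in place of the carbonyl of the shared core would read differently from these four compounds.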